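Compound 2 and a missing hydroxyphenyl neighbour

The compounds below may be only part of what the source reports. "The series", "measured", "known", "first", "only" and "open" are said of these compounds alone.

Measured so far in a physicochemical assay for lipophilicity, measured as octanol-water partition, at pH 7.4; on this read-out lower numbers stand for lower lipophilicity and higher numbers for higher lipophilicity:
- compound 1 (`CC(=O)N[C@H](C(=O)N1C[C@H](O)C[C@H]1C(=O)N[C@@H](CCc1ccc(Br)cc1)c1ccc(-c2scnc2C)cc1)C(C)(C)C`) gives 4.08
- compound 2 (`CCCC[C@H](NC(=O)[C@@H]1C[C@@H](O)CN1C(=O)[C@@H](NC(C)=O)C(C)(C)C)c1ccc(-c2scnc2C)cc1`) gives 2.75

Compound 2 holds the lower of the two numbers. Among the compounds with values here, the single measured step (a number 1.33 log units lower from compound 1 to compound 2 (beyond the scatter)) put ethyl in place of 4-bromophenyl and was large. Compound 3 (`CC(=O)N[C@H](C(=O)N1C[C@H](O)C[C@H]1C(=O)N[C@@H](CCc1ccc(O)cc1)c1ccc(-c2scnc2C)cc1)C(C)(C)C`) has not been measured yet. Its structure puts 4-hydroxyphenyl in place of ethyl on a saturated chain carbon, three bonds along the chain from an amide-type nitrogen and an aromatic carbon.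

This swap runs opposite to the measured step, since an aromatic ring returns to the chain. On that evidence alone, a rise toward compound 1 at 4.08 could be expected in this assay. However, the entering group is not 4-bromophenyl, and no measured compound carries 4-hydroxyphenyl, so there is no reason to assume that the whole step returns. The expected change is a small rise that may stay within the scatter (a number 0.15 log units higher from compound 2 to compound 3 (within the scatter)). Compound 3 is estimated at 2.9, with an expected range of 2.4 to 3.4 for the measurement.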

Compound 3, distribution coefficient: 3.08
Estimate against measurement, compound 3: 0.18 log units below; measured number inside the range.
By their numbers in this assay, from the lowest: compound 2; then compound 3; then compound 1.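

At this position on the chain, the ring and what it carries can now be read separately in this assay. Putting 4-hydroxyphenyl in place of ethyl gives a number 0.33 log units higher from compound 2 to compound 3 (beyond the scatter) and so recovers only a small part of the gap to the bromo compound, while hydroxy in place of bromo on an aromatic carbon gives a number 1.00 log units lower from compound 1 to compound 3 (beyond the scatter) and is the larger of the two steps. The earlier pair changed the ring and the bromo together and could not separate them, but the new compound shows that the group on the ring matters more to this number than the exchange of ethyl for a hydroxy-bearing ring, and nothing available here explains that difference.

The compounds shown leave open what a plain phenyl in this same place would give, which would separate the ring itself from its hydroxy or bromo. Also open is where an amine or a carboxylic acid on that aromatic carbon, or a longer chain in place of ethyl, would fall among these numbers.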